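This account rests on a few compounds, and the source may have more. Where it says the series, first, only, none or still open, it means among the compounds named here.

Measured so far: compound 1 `O=C(O)c1ccccc1-c1ccc(CCc2ncc(CCC3CCCCC3)[nH]2)cc1` with 642 nM; compound 2 `O=C(O)c1ccccc1-c1ccc(CCc2ncc(-c3ccccc3)[nH]2)cc1` with 4950 nM; compound 3 `CCCCc1cnc(CCc2ccc(-c3ccccc3C(=O)O)cc2)[nH]1` with 2710 nM, all in an in vitro functional assay on cells for agonist activity at Bombesin receptor subtype-3 (Homo sapiens), read by luminescence and calcium flux; on this read-out higher numbers stand for an effect only at larger amounts of compound and lower numbers for an effect already at smaller amounts.

Compound 3 holds the second highest of the three numbers; its gap to compound 2 lies within the scatter, whereas compound 1 sits clearly lower, as a 4.2-fold higher number from compound 1 to compound 3 (0.63 log units; beyond the scatter) shows. Compound 4 `Cc1cccc(Cc2cnc(CCc3ccc(-c4ccccc4C(=O)O)cc3)[nH]2)c1` differs from compound 3 by 3-methylphenyl in place of propyl on a saturated chain carbon bound to an aromatic carbon; cut one bond further out, the change reads butyl to 3-methylbenzyl. For the measured compounds named here, two measured steps bear on this: a 7.7-fold higher number from compound 1 to compound 2 (0.89 log units; beyond the scatter) and a 1.8-fold lower number from compound 2 to compound 3 (0.26 log units; within the scatter). A phenyl set directly on the aromatic carbon did not help, while butyl and phenyl there lay within the scatter of each other. With the ring here one carbon removed, no step beyond the scatter is expected for compound 4, estimated at 1800 nM (range 600 nM to 5500 nM), corresponding to a 1.5-fold lower number from compound 3 to compound 4 (0.18 log units; within the scatter).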

Compound 4, half-maximal effective concentration: 4310 nM
Beside the measured number, compound 4's estimate is 2.4-fold (0.38 log units) below it; the measured number falls inside the stated range.
By their numbers in this assay, from the lowest: compound 1; then compounds 3, 4 and 2 (each within the scatter of the next).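

In this assay, 3-methylbenzyl at this aromatic carbon stays within the scatter of butyl (a 1.6-fold higher number from compound 3 to compound 4 (0.20 log units; within the scatter)) and of phenyl (a 1.1-fold lower number from compound 2 to compound 4 (0.06 log units; within the scatter)). Moving the aromatic ring one carbon out from the aromatic carbon thus shows no separation from the directly attached phenyl, while 2-cyclohexylethyl remains apart (a 6.7-fold higher number from compound 1 to compound 4 (0.83 log units; beyond the scatter)). Nothing at hand accounts for this result. The compounds shown leave open whether 2-phenylethyl would match 2-cyclohexylethyl, which would separate chain length from ring type. They also leave open how an amine at the end of the chain would read.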